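The compounds below may be only part of what the source reports. "The series", "measured", "known", "first", "only" and "open" are said of these compounds alone.

Of the compounds shown here, three sharing the same amide core have so far been tested in an assay on HeLa cells with Bile acid receptor (Homo sapiens) as the target, read by a luciferase reporter, with a stated time of 24 h; a lower number here means that less compound is needed, a higher number that more compound is needed for the effect. Compound 1 `CC(C)Oc1ccc(CNC(=O)c2ccc(C(C)(C)C)cc2)cc1` gives 170 nM in this assay. Compound 2 `O=C(O)c1ccc(CNC(=O)c2ccc3ccccc3c2)cc1` gives 1360 nM, the highest of the three numbers. Compound 3 `CC(NC(=O)c1ccc(C(C)(C)C)cc1)c1ccc(C(=O)O)cc1` gives 76 nM, the lowest of the three. Compound 1 therefore stands second highest: its nearest neighbour is compound 3, whose number lies below it by a gap beyond the usual scatter, and its furthest is compound 2, whose number lies well above it, again beyond the scatter.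

The next compound, compound 4 `COc1ccc(CNC(=O)c2ccc(C(C)(C)C)cc2)cc1`, differs from compound 1 in a single place: methyl in place of isopropyl on an oxygen on an aromatic ring. For the measured compounds named here, none of the measured pairs shows this particular change, since compound 2 and compound 3 differ from compound 1 elsewhere, so there is no direct precedent among the three numbers. Going by the values given here, with no such precedent, the sensible expectation is a small step, most likely a modest rise in the number, though a result within the scatter of compound 1 would not surprise. The step of a 1.8-fold higher number from compound 1 to compound 4 (0.25 log units; within the scatter) is thus expected to be modest. Compound 4 is estimated to give about 300 nM, within a range from 120 nM to 800 nM.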

Compound 4, half-maximal effective concentration: 150 nM
Compound 4: the middle estimate sits 2.0-fold (0.30 log units) above what was measured; low and high end bracket the measured number.
By their numbers in this assay, from the lowest: compounds 3, 4 and 1 (each within the scatter of the next, the first and the last beyond it); then compound 2.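

In this assay, the change from isopropoxy to methoxy gives a 1.1-fold lower number from compound 1 to compound 4 (0.05 log units; within the scatter), so the two compounds cannot be told apart on this reading. For the compounds shown here, this is the first direct look at this place, on an oxygen on an aromatic ring, and it shows that on the core of compound 1 an isopropyl with its 3 carbons can give way to a methyl with its 1 carbon without a shift beyond the usual scatter of the measurement. Going by these compounds alone, nothing available explains this flat result, so the pair records only that the number holds across this one change, not what lies behind it.

Going by these compounds, the two groups compared are both small carbon groups, so it remains open how the number would respond to a longer chain such as butyl, or to a hydroxyl or an amine at this place. One pair also cannot show whether the same change would read the same way on a core other than that of compound 1.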